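The source may report more compounds than this note shows. Statements on the series, on what has been measured and on what is new or still open speak of the compounds shown alone.

Measured so far in an assay on cells for displacement of a labelled ligand from prostaglandin E2 receptor EP4 subtype (Homo sapiens), read by scintillation counting; on this read-out higher numbers stand for weaker inhibition and lower numbers for stronger inhibition: compound 1 `Cc1oc(C(=O)O)cc1COc1ccc(-c2ccc(Cl)cc2)cc1` gives 1000 nM; compound 2 `COc1ccccc1-c1ccc(OCc2cc(C(=O)O)oc2C)cc1` gives 1600 nM.

Compound 2 shows the higher of the two numbers, but its gap to compound 1, a 1.6-fold higher number from compound 1 to compound 2 (0.20 log units; within the scatter), lies within the scatter. Compound 3 `Cc1oc(C(=O)O)cc1COc1ccc(-c2ccoc2)cc1` differs from compound 2 by furan-3-yl in place of 2-methoxyphenyl on an aromatic carbon. Among the compounds with values here, the one measured step, a 1.6-fold higher number from compound 1 to compound 2 (0.20 log units; within the scatter), also exchanged the terminal aromatic group and stayed within the scatter, so it bears on this change only loosely. The step to compound 3 is therefore expected to be small, a 1.6-fold higher number from compound 2 to compound 3 (0.19 log units; within the scatter), if anything toward a higher number. Compound 3 is estimated at 2500 nM, within 800 nM to 8000 nM.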

Compound 3, inhibition constant: > 10000 nM
Compound 3: no number, only a limit; the forecaster's own chance of this, stated with the estimate: 10%; middle value at least 4.0-fold (0.60 log units) from the limit.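

At this place on the ring, para to a large group, the exchange of one terminal aromatic group for another is not always neutral in this assay: furan-3-yl in place of 2-methoxyphenyl gives an at least 6.2-fold higher number from compound 2 to compound 3 (0.79 log units; beyond the scatter), and in place of 4-chlorophenyl it gives an at least 10-fold higher number from compound 1 to compound 3 (1.00 log units; beyond the scatter). The earlier step between the two six-membered rings had stayed within the scatter. Compound 3 gives a limit and not a number, so the true size of both steps stays unknown: the limit of > 10000 nM in this assay, at which 1 of the 3 values shown sits.

The compounds shown do not separate the effect of ring size from that of the ring oxygen or the smaller group. A plain phenyl or a thiophen-3-yl at this place would bear on that question.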